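Swapping Trifluoromethyl for Fluoro on the Aromatic Ring

A few compounds are considered here, and "the series" means these few. Any claim that something is new, unique, unknown or untested is made for them only; others in the source may bear on it.

Measured so far in a functional assay with Neuronal acetylcholine receptor; alpha3/beta4 (Homo sapiens) as the target; on this read-out lower numbers stand for stronger inhibition and higher numbers for weaker inhibition:
Compound 1, `CCC1CC(=O)N(c2ccccc2C(=O)OCC2CCCN(CCCc3ccccc3)C2)C1=O`, gives 4500 nM.
Compound 2, `CC(C)C1CC(=O)N(c2ccccc2C(=O)OCC2CCCN(CCCc3ccccc3)C2)C1=O`, gives 2500 nM.
Compound 3, `O=C(OCC1CCCN(CCCc2ccccc2)C1)c1ccccc1C(F)(F)F`, gives 3200 nM.

Compound 3 lies within the usual scatter of both other compounds: a 1.4-fold lower number from compound 1 to compound 3 (0.15 log units; within the scatter) and a 1.3-fold higher number from compound 2 to compound 3 (0.11 log units; within the scatter). Each of those steps put trifluoromethyl on the same aromatic carbon in place of a larger ring-bearing group, and neither moved this assay beyond the scatter. Compound 4, `O=C(OCC1CCCN(CCCc2ccccc2)C1)c1ccccc1F`, changes that same carbon once more: fluoro in place of trifluoromethyl on an aromatic carbon. Given a 1.4-fold lower number from compound 1 to compound 3 (0.15 log units; within the scatter) and a 1.3-fold higher number from compound 2 to compound 3 (0.11 log units; within the scatter), the expected step is a 1.1-fold higher number from compound 3 to compound 4 (0.04 log units; within the scatter), meaning no shift beyond the scatter is anticipated. Compound 4 is therefore estimated at 3500 nM in this assay, with a likely range from 1200 nM to 10000 nM.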

Compound 4, half-maximal inhibitory concentration: 5200 nM
For compound 4 the middle estimate is 1.5-fold (0.17 log units) below the measured one; the range from low to high includes it.
By their numbers in this assay, from the lowest: compounds 2, 3, 1 and 4 (each within the scatter of the next, the first and the last beyond it).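

In this assay fluoro in place of trifluoromethyl gives a 1.6-fold higher number from compound 3 to compound 4 (0.21 log units; within the scatter) on this aromatic carbon, so even a single fluorine atom keeps the number within the scatter. One fluorine atom in place of the ring-bearing group gives a 1.2-fold higher number from compound 1 to compound 4 (0.06 log units; within the scatter) and again stays within the scatter. Going by these compounds alone, only the step to the larger ring-bearing group of compound 2, seen as a 2.1-fold higher number from compound 2 to compound 4 (0.32 log units; beyond the scatter) and modest, passes the scatter. Whether an amine or a carboxylic acid on this carbon would shift the number remains open, and nothing available here explains these steps.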